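Replacing nitro in compound 2: the step to compound 3

This account rests on a few compounds, and the source may have more. Where it says the series, first, only, none or still open, it means among the compounds named here.

Going by the values given here, in a functional assay on GC3/MTK- cells (Homo sapiens) for inhibition (on this read-out higher numbers stand for weaker inhibition and lower numbers for stronger inhibition), compound 2 `C#CCN(Cc1ccc2nc(C)nc(O)c2c1)c1ccc([N+](=O)[O-])cc1` gives 4800 nM, the only number so far. Compound 1 `C#CCN(Cc1ccc2nc(C)nc(O)c2c1)c1cccc(I)c1` is reported only as a limit, > 5300 nM, and offers no exact value for comparison.

The next compound to be read is compound 3 `C#CCN(Cc1ccc2nc(C)nc(O)c2c1)c1ccc(S(=O)(=O)N2CCOCC2)cc1`, which differs from compound 2 by (morpholin-4-yl)sulfonyl in place of nitro on an aromatic carbon. In words, (morpholin-4-yl)sulfonyl stands in place of nitro on an aromatic carbon, para to a large group. Among the compounds with values here, no measured pair covers this change or any similar one.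

With compound 2 at 4800 nM as the sole anchor, no change beyond the scatter is expected in this assay. The expected step is a 1.1-fold lower number from compound 2 to compound 3 (0.03 log units; within the scatter). For compound 3 the estimated value is 4500 nM, with an expected range of 1500 nM to 13000 nM.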

Compound 3, half-maximal inhibitory concentration: 5200 nM
Estimate against measurement, compound 3: 1.2-fold (0.06 log units) below; the range from low to high includes it.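

In this assay, going by these compounds alone, the one step at this place is a 1.1-fold higher number from compound 2 to compound 3 (0.03 log units; within the scatter), with (morpholin-4-yl)sulfonyl in place of nitro on an aromatic carbon, para to a large group. Within the data shown here, this position therefore takes a far larger group, one carrying a six-membered non-aromatic ring, with no change beyond the scatter, which the earlier compounds could not show. The reach of this flat step is limited, since compound 1 is held only as a limit: the limit of > 5300 nM in this assay, at which 1 of the 3 values shown sits.

From the compounds shown here alone, whether any group at this place can bring the number down stays open, for instance an amine, a carboxylic acid or a simple methyl. Going by these compounds, all three compounds carry the shared core unchanged, and what a change there would do in this assay also stays open.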